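This account rests on a few compounds, and the source may have more. Where it says the series, first, only, none or still open, it means among the compounds named here.

Measured in an ADME assay on isolated protein for inhibition of protein deacetylase HDAC6 (Homo sapiens), read by fluorescence, with stated times of 5 min and 30 min; on this read-out higher numbers stand for weaker inhibition and lower numbers for stronger inhibition: compound 1 `C[C@H](NS(=O)(=O)c1cccc(C(=O)NO)c1)C(=O)Nc1ccccc1`, 27700 nM; compound 2 `O=C(NO)c1cccc(S(=O)(=O)Nc2ccccc2)c1`, 1500 nM.

Compound 2 has the lower of the two numbers, and compound 1 stands well apart from it, beyond the scatter. Compound 3 `O=C(NO)c1cccc(S(=O)(=O)NCc2ccccc2)c1` has not been measured. The change from compound 2 to compound 3 is benzyl in place of phenyl on a sulfonamide nitrogen. No such step between measured compounds is known here, so nothing shown tells how large it is. The step is expected to be a 1.3-fold lower number from compound 2 to compound 3 (0.10 log units; within the scatter), not beyond the scatter. Compound 3 is therefore expected to give about 1200 nM, within a range from 300 nM to 5000 nM.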

Compound 3, half-maximal inhibitory concentration: 2600 nM
Compound 3: middle estimate off by 2.2-fold (0.34 log units), on the low side; measured number inside the range.
By their numbers in this assay, from the lowest: compounds 2 and 3 (each within the scatter of the next); then compound 1.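

In this assay the swap of phenyl for benzyl on the sulfonamide nitrogen gives a 1.7-fold higher number from compound 2 to compound 3 (0.24 log units; within the scatter) and so stays within the scatter. This position therefore takes the benzyl group, with its one added carbon, without a change that this assay can separate from noise. Nothing available explains this result.

Only these two groups have been compared at this position in a single step. Going by these compounds, how a longer chain such as phenylethyl, or a benzyl ring carrying an amine or a carboxylic acid, would read remains open.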